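The compounds below may be only part of what the source reports. "The series", "measured", "known", "first", "only" and "open" are said of these compounds alone.

Among the measured compounds shown here, in a functional assay on KYSE-450 cells (Homo sapiens) for inhibition, read by MTT assay, with a stated time of 48 h (a lower number here means a stronger inhibitor, a higher number a weaker inhibitor), three compounds have numbers so far. Compound 1 `COc1cc(NCc2ccccc2)cc(OC)c1OC` stands only at the limit of > 80000 nM there. Since that is an assay limit (the limit of > 80000 nM in this assay, at which 1 of the 3 values shown sits), the step of an at least 1.1-fold lower number from compound 1 to compound 3 (0.05 log units; that floor lies within the scatter) is only a floor. Compound 3 `COc1cc(NCc2cccc(O)c2)cc(OC)c1OC` gives 71300 nM in this assay. For the measured compounds named here, compound 2 `C=C(C)C(=O)N(Cc1ccc(OC)c(O)c1)c1cc(OC)c(OC)c(OC)c1` gives 200 nM in this assay, the lowest of the two numbers known and beyond the scatter from compound 3. Compound 4 `COc1ccc(CN(C(=O)/C=C/CBr)c2cc(OC)c(OC)c(OC)c2)cc1O` differs from compound 2 in one place (3-bromoprop-1-en-1-yl in place of 1-methylethenyl on a carbonyl carbon). Going by the values given here, the single measured step concerns a hydroxy group on an aromatic carbon and leaves the carbonyl untouched, so no measured step bears on this change. Compound 4 is therefore expected at about 150 nM in this assay, between 40 nM and 600 nM. The expected step of a 1.3-fold lower number from compound 2 to compound 4 (0.12 log units; within the scatter) stays within the scatter.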

Compound 4, half-maximal inhibitory concentration: 100 nM
Beside the measured number, compound 4's estimate is 1.5-fold (0.18 log units) above it, within the range that was stated.
By their numbers in this assay, from the lowest: compounds 4 and 2 (each within the scatter of the next); then compound 3. At a limit, above all of these: compound 1.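

The earlier compounds shown here held no change at this place, on a carbonyl carbon whose other neighbour is an amide-type nitrogen. In this assay putting 3-bromoprop-1-en-1-yl in place of 1-methylethenyl there gives a 2.0-fold lower number from compound 2 to compound 4 (0.30 log units; within the scatter) and that step lies within the scatter, so this read-out does not separate the two groups. Nothing measured here accounts for this result. The compounds shown leave open how this place responds to a group without bromine, such as an amine or a carboxylic acid. As far as these compounds go, a longer chain remains equally open.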